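From carbamoyl to carbonyloxy link: expectation for compound 4

The source may report more compounds than this note shows. Statements on the series, on what has been measured and on what is new or still open speak of the compounds shown alone.

Of the compounds shown here, three on the shared core have been read in a functional assay on HBC4 cells (Homo sapiens) for inhibition, read by sulforhodamine B assay, with a stated time of 48 h (on this read-out higher numbers stand for weaker inhibition of growth and lower numbers for stronger inhibition of growth), so far. Compound 1 (`CCCCCCCCCCCC[C@@H](O)[C@H]1CC[C@H]([C@H](O)CCCCCCCCCCNC(=O)c2ccnn2C)O1`) gives 100000 nM on this read-out. Compound 2 (`CCCCCCCCCCCC[C@@H](O)[C@H]1CC[C@H]([C@H](O)CCCCCCCCCCN(C)C(=O)c2ccnn2C)O1`) gives 10000 nM on the same read-out. Compound 3 (`CCCCCCCCCCCC[C@@H](O)[C@H]1CC[C@H]([C@H](O)CCCCCCCCCCC(=O)Nc2ccnn2C)O1`) gives 100000 nM and stands level with compound 1, the two sharing the highest number of the three.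

The next step leads to compound 4 (`CCCCCCCCCCCC[C@@H](O)[C@H]1CC[C@H]([C@H](O)CCCCCCCCCCOC(=O)c2ccnn2C)O1`), with this change on a saturated chain carbon: ((1-methyl-1H-pyrazol-5-yl)carbonyl)oxy in place of (1-methyl-1H-pyrazol-5-yl)carbamoyl on a saturated chain carbon, ten or more bonds along the chain from an oxygen on a saturated carbon and a saturated ring carbon. Compound 4 therefore has ((1-methyl-1H-pyrazol-5-yl)carbonyl)oxy where compound 3 has (1-methyl-1H-pyrazol-5-yl)carbamoyl.

Two kinds of measured step bear on this. Swapping the link on the same chain carbon gave no change at the digits printed from compound 1 to compound 3 (within the scatter) in the notes so far. Methyl in place of hydrogen on the amide-type nitrogen gave a 10-fold lower number from compound 1 to compound 2 (1.00 log units; beyond the scatter) and is the only change that has moved the number, with a 10-fold higher number from compound 2 to compound 3 (1.00 log units; beyond the scatter) as its mirror. Within the data shown here, compound 4 resembles compound 2 in lacking an amide hydrogen, but no measured compound carries the new link, so this analogy is weak. Only part of that shift is expected to carry over, and the expected result is a 3.3-fold lower number from compound 3 to compound 4 (0.52 log units; beyond the scatter) in this assay, toward a lower number. Compound 4 is estimated at 30000 nM, with an expected range from 8000 nM to 100000 nM on this read-out.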

Compound 4, concentration for 50% growth inhibition: 51300 nM
Compound 4: middle estimate off by 1.7-fold (0.23 log units), on the low side, within the range that was stated.
By their numbers in this assay, from the lowest: compound 2; then compounds 4, 1 and 3 (each within the scatter of the next).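

Notes on the saturated chain carbon: in this assay, ((1-methyl-1H-pyrazol-5-yl)carbonyl)oxy in place of (1-methyl-1H-pyrazol-5-yl)carbamoyl gives (a 1.9-fold lower number from compound 3 to compound 4 (0.29 log units; within the scatter)), and in place of ((1-methyl-1H-pyrazol-5-yl)carbonyl)amino it gives (a 1.9-fold lower number from compound 1 to compound 4 (0.29 log units; within the scatter)), so this third link does not separate from the two secondary amide-type links. Having no hydrogen-bond donor in the link does not by itself match compound 2, as methyl((1-methyl-1H-pyrazol-5-yl)carbonyl)amino changing to ((1-methyl-1H-pyrazol-5-yl)carbonyl)oxy gives (a 5.1-fold higher number from compound 2 to compound 4 (0.71 log units; beyond the scatter)), which leaves the methylated amide-type link as the only one here set apart beyond the scatter from all the others. No supporting measurement is available to account for this difference.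

From the compounds shown here alone, it remains open whether methyl on the nitrogen of the (1-methyl-1H-pyrazol-5-yl)carbamoyl link would repeat the step seen on the other amide orientation (a 10-fold lower number from compound 1 to compound 2 (1.00 log units; beyond the scatter)). Also open, going by these compounds, is how this assay would respond to an amine link, a carboxylic acid at the chain end or a longer chain at this position.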